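Sulfanyl in Place of Chloro: Two Matched Pairs

A few compounds are considered here, and "the series" means these few. Any claim that something is new, unique, unknown or untested is made for them only; others in the source may bear on it.

Compound 1 `CC(=O)OC(C)n1cnc2c(Cl)nc(N)nc21` and compound 3 `CC(=O)OC(C)n1cnc2c(S)nc(N)nc21` differ in a single place: sulfanyl in place of chloro on an aromatic carbon. In a functional assay on L1210 cells (Mus musculus) for inhibition (on this read-out lower numbers stand for stronger inhibition and higher numbers for weaker inhibition), compound 1 gives only a limit of the assay, > 500000 nM. Compound 3 gives 128000 nM. On these data alone, the step is an at least 3.9-fold lower number from compound 1 to compound 3 (0.59 log units; beyond the scatter); its exact size stays open at the limit of > 500000 nM in this assay, at which 2 of the 3 values shown sit. Compound 2 `CC(=O)OCCOn1cnc2c(Cl)nc(N)nc21` and compound 4 `CC(=O)OCCOn1cnc2c(S)nc(N)nc21` form a second pair carrying the same change, (sulfanyl in place of chloro on an aromatic carbon). How the core of compound 2 differs from the core of compound 1 is not broken down here. In this assay compound 2 also gives only a limit, > 500000 nM. Compound 4 is expected to show an at least 2.5-fold lower number from compound 2 to compound 4 (0.39 log units; beyond the scatter), an expectation resting on an at least 3.9-fold lower number from compound 1 to compound 3 (0.59 log units; beyond the scatter). The estimate for compound 4 is 200000 nM, with a likely range from 60000 nM to 600000 nM.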

Compound 4, half-maximal inhibitory concentration: 3200 nM
Beside the measured number, compound 4's estimate is 63-fold (1.80 log units) above it, outside the stated range (below it).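

In this assay the swap on the second core gives an at least 150-fold lower number from compound 2 to compound 4 (2.19 log units; beyond the scatter), so the direction of the change carries over from one core to the other. Whether the change is worth more on one core than on the other cannot be said: the same change on two cores in this assay, an at least 3.9-fold lower number (0.59 log units; beyond the scatter) from compound 1 to compound 3 and an at least 150-fold lower number (2.19 log units; beyond the scatter) from compound 2 to compound 4; the limit leaves it open whether they differ. Both chloro compounds stop at a limit of the assay, so each step gives only a minimum size rather than a full one: the limit of > 500000 nM in this assay, at which 2 of the 4 values shown sit.

On these data alone, it remains open whether an amine or a hydroxyl group in the place of sulfanyl would also lower the number. As far as these compounds go, it is also open whether the step would hold on a third core, for example one carrying a longer chain.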